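A few compounds are considered here, and "the series" means these few. Any claim that something is new, unique, unknown or untested is made for them only; others in the source may bear on it.

The measured compounds:

compound 1 `CCn1c(CNc2ccccc2)nnc1SCC(=O)Nc1ccc(C(=O)OC)cc1`: in an assay on isolated protein for inhibition of long-chain fatty acid transport protein 1 (Mus musculus) (a lower number here means a stronger inhibitor, a higher number a weaker inhibitor), compound 1 gives "not determined" (no result reported).
compound 2 `CC/C(=N/O)c1ccc2oc(CSc3nnc(CNc4ccccc4)n3CC)nc2c1`: in this assay compound 2 gives 200 nM.

Compound 1 carries the shared core, a triazole bearing an ethyl group and an anilinomethyl arm, joined through a sulfur-linked acetamide to a phenyl ring that ends in a methoxycarbonyl group. Where compound 1 stands in this assay cannot be said from a number, since none was reported for it. Among the measured compounds shown here, compound 2 keeps the same triazole core but replaces the acetamide part with a different ring system that bears an oxime; it is the only compound of the set with a number in this assay.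

Compound 3 `CCn1c(CNc2ccccc2)nnc1SCC(=O)Nc1ccc(OC)cc1` is the subject of the step from compound 1. The change is methoxy in place of methoxycarbonyl on an aromatic carbon, at the position para to a large group. For the measured compounds named here, no step between measured compounds is available for this change, and compound 1 itself has no value, so the size of the step cannot be anchored; it is expected to stay within the scatter or to shift the number only modestly in either direction. Compound 3 is estimated to give 2000 nM in this assay, within the range 300 nM to 15000 nM.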

Compound 3, half-maximal inhibitory concentration: > 10000 nM
Compound 3: a limit, no number (the forecaster's own chance of this, stated with the estimate: 30%); middle value at least 5.0-fold (0.69 log units) from the limit.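

No new step can be read between compound 1 and compound 3; compound 1 carries no number in this assay. Compound 3 gives > 10000 nM, which is a limit and not a number. The compounds shown leave open how far the change from 4-(methoxycarbonyl)phenyl to 4-methoxyphenyl moves the result in this assay.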